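Ring Size at the Amide: Compound 3 to Compound 4

A few compounds are considered here, and "the series" means these few. Any claim that something is new, unique, unknown or untested is made for them only; others in the source may bear on it.

Three compounds have been measured in an assay on cells for inhibition of Palmitoleoyl-protein carboxylesterase NOTUM variant C330S (Homo sapiens), read by fluorescence, with a stated time of 40 min; a higher number here means a weaker inhibitor, a lower number a stronger inhibitor:

Compound 1, `CN(C)C(=O)C1CCN(c2ccc(Cl)c(C(F)(F)F)c2)C1`, gives 1200 nM.
Compound 2, `O=C(C1CCN(c2ccc(Cl)c(C(F)(F)F)c2)C1)N1CC2COCC2C1`, gives 3100 nM.
Compound 3, `CN1CN(C(=O)C2CCN(c3ccc(Cl)c(C(F)(F)F)c3)C2)CC1=O`, gives 1400 nM.

All three share the same core and differ only in the group carried on the carbonyl carbon. Compound 3 holds the second highest number of the three. Its nearest neighbour is compound 1, and the step of a 1.2-fold higher number from compound 1 to compound 3 (0.07 log units; within the scatter) cannot be told from repeat measurement. Its furthest neighbour is compound 2, and the step of a 2.2-fold lower number from compound 2 to compound 3 (0.35 log units; beyond the scatter) is real but modest.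

Compound 4, `CN1CCN(C(=O)C2CCN(c3ccc(Cl)c(C(F)(F)F)c3)C2)CC1=O`, is the next member. The change from compound 3 is a group of 8 heavy atoms (5 carbon, 2 nitrogen, 1 oxygen; one six-membered non-aromatic ring with 2 hetero atoms) in place of a group of 7 heavy atoms (4 carbon, 2 nitrogen, 1 oxygen; one five-membered non-aromatic ring with 2 hetero atoms), on a carbonyl carbon. Every measured step concerns the same position. The step of a 2.6-fold higher number from compound 1 to compound 2 (0.41 log units; beyond the scatter) shows that a larger, two-ring group costs a little; the step of a 1.2-fold higher number from compound 1 to compound 3 (0.07 log units; within the scatter) shows that a single five-membered ring with two hetero atoms costs nothing detectable. Widening that ring by one carbon, with the counted donors and acceptors unchanged, is a smaller move than either of those. The step of a 1.1-fold higher number from compound 3 to compound 4 (0.03 log units; within the scatter) is therefore expected to stay within the scatter. Compound 4 is estimated at 1500 nM, with a likely range from 600 nM to 4000 nM.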

Compound 4, half-maximal inhibitory concentration: 3100 nM
Beside the measured number, compound 4's estimate is 2.1-fold (0.32 log units) below it; the range from low to high includes it.
By their numbers in this assay, from the lowest: compounds 1 and 3 (each within the scatter of the next); then compounds 2 and 4 (each within the scatter of the next).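

In this assay, this position on the carbonyl carbon responds even to widening a five-membered ring to the six-membered ring of 4-methyl-3-oxopiperazin-1-yl, since a 2.2-fold higher number from compound 3 to compound 4 (0.35 log units; beyond the scatter) is a modest change but lies beyond the scatter, even though the counted donors and acceptors stay the same. The earlier compounds shown here suggested that a single ring could be carried at no detectable cost, but that holds for compound 3 and not for compound 4, so having one ring rather than two does not by itself settle the result here. Compound 4 in fact matches the two-ring group of compound 2, with no change at the digits printed from compound 2 to compound 4 (within the scatter) to show for it, and the comparison with the small dimethylamino group gives a 2.6-fold higher number from compound 1 to compound 4 (0.41 log units; beyond the scatter) as the price of this six-membered ring.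

The compounds shown leave open whether the ring carbonyl or the methyl on the ring nitrogen plays any part in this result, which a morpholin-4-yl or a plain piperidin-1-yl group on the same carbonyl carbon could begin to test. Nothing available here accounts for the gap between the two ring sizes.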